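Compound 3 and its trifluoromethyl counterpart

The source may hold more compounds than are shown below. What is called first, only, known or untested is meant among the compounds shown, and "the series" means these compounds.

In a functional assay on HL-60 cells (Homo sapiens) for inhibition, read by MTT assay, with a stated time of 72 h (on this read-out lower numbers stand for stronger inhibition and higher numbers for weaker inhibition), compound 1 `Cc1nc(-c2ccccc2F)c(C(=O)N2CCN(c3cc(Cl)cc(Cl)c3)CC2)s1` gives 157 nM as its measured value, and compound 2 `Cc1ccc(C)c(N2CCN(C(=O)c3oc(C)nc3-c3ccc(F)cc3)CC2)c1` gives 358 nM as its own. Compound 3 `C=C(C)c1ccc(N2CCN(C(=O)c3oc(C)nc3-c3ccccc3)CC2)cc1` is recorded as "not active" (no number reported) with no number attached, so it stands apart from both. Compound 4 `Cc1nc(-c2ccccc2)c(C(=O)N2CCN(c3ccc(C(F)(F)F)cc3)CC2)o1` has not been measured yet. The structural change is trifluoromethyl in place of 1-methylethenyl on an aromatic carbon and it puts trifluoromethyl in place of 1-methylethenyl on an aromatic carbon, para to a large group. Among the compounds with values here, no measured pair shows what this change does. A modest step toward stronger inhibition in this assay is expected, though compound 4 could also end up without a number. Compound 4 is estimated at 800 nM with an expected range from 200 nM to 4000 nM in this read-out.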

Compound 4, half-maximal inhibitory concentration: > 1000 nM
Compound 4: a limit, no number; the forecaster's own chance of this, stated with the estimate: 35%; at least 1.2-fold (0.09 log units) between middle value and limit.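

No step can be read from compound 3 to compound 4: compound 3 carries no number, and compound 4 carries only a limit. Going by these compounds, whether trifluoromethyl in place of 1-methylethenyl strengthens, weakens or leaves inhibition unchanged stays open.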